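The compounds below may be only part of what the source reports. "The series", "measured", "known", "first", "only" and "open" are said of these compounds alone.

Measured so far in a physicochemical assay for solubility, at pH 7.4 (a higher number here means a more soluble compound, a lower number a less soluble compound), are two compounds.
Compound 1 `COc1ccc(NC(=O)Nc2cc(C)nc3ccccc23)cc1Cl` gives 400 nM
Compound 2 `Cc1cc(NC(=O)Nc2ccc(C(F)(F)F)cc2)c2ccccc2n1` gives 100 nM

Compound 2 has the lower of the two numbers, and its gap to compound 1 lies beyond the scatter. Compound 3 `COc1ccc(NC(=O)Nc2cc(C)nc3ccccc23)cc1` has not yet been measured. It differs from compound 2 by methoxy in place of trifluoromethyl on an aromatic carbon, para to a large group (methoxy in place of trifluoromethyl on an aromatic carbon). Among the compounds with values here, no measured pair isolates this change, so the guide is thin: compound 1, which also carries methoxy, gives 400 nM and points upward. In this assay an upward move beyond the scatter is expected, with a 6.0-fold higher number from compound 2 to compound 3 (0.78 log units; beyond the scatter) as the estimate. For compound 3 the estimated value is 600 nM (range 200 nM to 1800 nM).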

Compound 3, solubility: 19800 nM
Beside the measured number, compound 3's estimate is 33-fold (1.52 log units) below it, outside the stated range (above it).
By their numbers in this assay, from the lowest: compound 2; then compound 1; then compound 3.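

In this assay, methoxy in place of trifluoromethyl on this aromatic carbon gives a 200-fold higher number from compound 2 to compound 3 (2.30 log units; beyond the scatter), so the group at this position can shift the read-out strongly. Hydrogen in place of chloro on an aromatic carbon gives a 50-fold higher number from compound 1 to compound 3 (1.69 log units; beyond the scatter), showing that a single atom swap elsewhere on the same ring can matter greatly too. Nothing available here explains either step.

Still open, as far as these compounds go, is whether an amine, a carboxylic acid or a longer chain such as ethoxy at this position would give a similarly high number. Also open, from the compounds shown here alone, is how a plain hydrogen there would compare with methoxy.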